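The compounds below may be only part of what the source reports. "The series", "measured", "known", "first", "only" and "open" are said of these compounds alone.

Measured so far, in an ADME assay on HEL cells (Homo sapiens) for cytotoxicity; a higher number here means that more compound is tolerated, a lower number that less compound is tolerated:
compound 1 `O=C(COc1cccc2ccccc12)N/N=C/c1ccccc1Br` gives 100 ug/mL
compound 2 `C/C(=N\NC(=O)COc1cccc2ccccc12)c1ccc(O)cc1O` gives 74.8 ug/mL
compound 3 `C/C(=N\NC(=O)COc1cccc2ccccc12)c1ccccc1Br` gives 16.2 ug/mL

Compound 1 stands at the highest of the three numbers. Compound 2 sits close to it, within the usual scatter, so the two cannot be ranked against each other; compound 3 lies clearly below both. Among the measured compounds shown here, the one step that can be read between two compounds differing in a single place is a 4.6-fold lower number from compound 2 to compound 3 (0.66 log units; beyond the scatter), which shows that exchanging the aromatic group on the carbon with a double bond to nitrogen can shift the read-out by a modest but real amount.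

Compound 4 `O=C(COc1cccc2ccccc12)N/N=C/c1cccc(Cl)c1` is reached from compound 1 by one change: 3-chlorophenyl in place of 2-bromophenyl on a carbon with a double bond to nitrogen. This is again an exchange of the aromatic group at that same carbon, but here one halogenated phenyl replaces another, whereas in the step from compound 2 to compound 3 a phenyl with two hydroxyl groups was replaced. For the measured compounds named here, no measured pair shows a halogen-for-halogen exchange, so the only guide is that such a swap tends to matter less than the one already seen. The expected outcome for compound 4 is a small shift, a 1.3-fold lower number from compound 1 to compound 4 (0.10 log units; within the scatter), not beyond the scatter. Compound 4 is therefore estimated at 80 ug/mL, with a range from 30 ug/mL to 200 ug/mL.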

Compound 4, half-maximal cytotoxic concentration: 58.6 ug/mL
Beside the measured number, compound 4's estimate is 1.4-fold (0.14 log units) above it, within the range that was stated.
By their numbers in this assay, from the lowest: compound 3; then compounds 4, 2 and 1 (each within the scatter of the next).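

In this assay, putting 3-chlorophenyl in place of 2-bromophenyl on a carbon with a double bond to nitrogen gives a 1.7-fold lower number from compound 1 to compound 4 (0.23 log units; within the scatter), so compound 1 and compound 4 cannot be ranked against each other. Among the compounds shown here, this is the first pair in which one halogen-bearing phenyl replaces another at this place, and it shows that the aromatic group here can be exchanged without a shift beyond the scatter, whereas the earlier exchange of a dihydroxyphenyl for a bromophenyl gave a 4.6-fold lower number from compound 2 to compound 3 (0.66 log units; beyond the scatter). Nothing at hand explains why this halogen exchange leaves the read-out within the scatter.

On these data alone, this single step changes both the halogen and the numbered place it holds on the phenyl, so how 2-chlorophenyl or 3-bromophenyl would compare with compound 1 remains open, and those two groups are what would separate one change from the other. Also open, as far as these compounds go, is whether a phenyl carrying a quite different substituent at this place, such as an amine or a carboxylic acid, would stay within the scatter of compound 1.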